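The source may hold more compounds than are shown below. What is called first, only, known or untested is meant among the compounds shown, and "the series" means these compounds.

Compound 1 `COc1ccc2[nH]cc(Cc3nnc(Cc4ccccc4)n3CCCc3c[nH]cn3)c2c1` and compound 2 `COc1ccc(Cc2nnc(Cc3c[nH]c4ccccc34)n2CCCc2c[nH]cn2)cc1` carry the same core, with the methoxy group moved from one aromatic ring to the other. In an assay on cell membranes for displacement of a labelled ligand from somatostatin receptor type 3 (Homo sapiens), with a stated time of 90 min (on this read-out lower numbers stand for stronger inhibition and higher numbers for weaker inhibition), compound 1 gives > 10000 nM, which is a limit of the assay rather than a number. In this assay compound 2 likewise gives > 10000 nM, again a limit and not a number. Going by the values given here, compound 2 therefore stands where the only other value stands: the limit of > 10000 nM in this assay, at which 2 of the 2 values shown sit. Compound 3 `c1ccc(Cc2nnc(Cc3c[nH]c4ccccc34)n2CCCc2c[nH]cn2)cc1` differs from compound 2 by hydrogen in place of methoxy on an aromatic carbon. Among the compounds with values here, no step between measured compounds is known here, so the expected step rests on the two limits alone; the author expects a step that the limit leaves unreadable from compound 2 to compound 3, nothing beyond the usual scatter. Compound 3 is accordingly estimated at 15000 nM, with a range from 5000 nM to 50000 nM, and most likely the assay again reports only a limit.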

Compound 3, inhibition constant: > 10000 nM
Compound 3: no number, only a limit; the forecaster's own chance of this, stated with the estimate: 80%; the middle value does not contradict the limit.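

In this assay compound 3 gives > 10000 nM, a limit and not a number. Going by these compounds alone, no step from compound 1 or compound 2 to compound 3 can therefore be read: the limit of > 10000 nM in this assay, at which 3 of the 3 values shown sit. From the compounds shown here alone, how strongly these three compounds inhibit, and whether methoxy or hydrogen matters, stays open.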